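A few compounds are considered here, and "the series" means these few. Any claim that something is new, unique, unknown or untested is made for them only; others in the source may bear on it.

Measured so far:
compound 1 `Cc1cc(-c2ccsc2)cn2c(CSCc3ccccc3)cnc12`: in an ADME assay on HEL cells (Homo sapiens) for cytotoxicity, with a stated time of 3 days (a lower number here means that less compound is tolerated, a higher number that more compound is tolerated), compound 1 gives 4 ug/mL
compound 2 `Cc1cc(N2CCCC2)cn2c(CSCCc3ccccc3)cnc12`: in this assay compound 2 gives 20 ug/mL
compound 3 `Cc1cc(N2CCCC2=O)c2ncc(CSCCc3ccccc3)n2c1`: in this assay compound 3 gives 20 ug/mL

Compound 3 stands level with compound 2 at the digits read, the two together at the top of the three numbers; the gap between them lies within the scatter, so no order is drawn between them. Compound 1 is furthest off, its number lower than that of compound 3 by an amount beyond the scatter. Among the measured compounds shown here, no step between measured compounds that differ in one place is available in this set.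

Compound 4 `Cc1cc(Sc2ccc(O)cc2)c2ncc(CSCCc3ccccc3)n2c1` has not yet been measured in this assay. It differs from compound 3 as follows: (4-hydroxyphenyl)sulfanyl in place of 2-oxopyrrolidin-1-yl on an aromatic carbon. For the measured compounds named here, with no matching step on record, the direction of this change cannot be read from the series; the only guide is that the three numbers span from compound 1 to compounds 2 and 3. A moderate step downward is expected, a 2.0-fold lower number from compound 3 to compound 4 (0.30 log units; within the scatter), without confidence in its size. Compound 4 is expected to give about 10 ug/mL in this assay, within a range from 4 ug/mL to 25 ug/mL.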

Compound 4, minimum cytotoxic concentration: > 100 ug/mL
Compound 4: a limit, no number; the forecaster's own chance of this, stated with the estimate: 15%; middle value at least 10-fold (1.00 log units) from the limit.
By their numbers in this assay, from the lowest: compound 1; then compounds 2 and 3 (each within the scatter of the next). At a limit, above all of these: compound 4.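

Among the compounds shown here, the group on this aromatic carbon, ortho to a fused ring, is the first single change that can be read, and it moves the reading: (4-hydroxyphenyl)sulfanyl in place of 2-oxopyrrolidin-1-yl gives an at least 5.0-fold higher number from compound 3 to compound 4 (0.69 log units; beyond the scatter). In this assay compound 4 gives > 100 ug/mL, which is a limit of the assay and not a number. The step therefore has a lower bound only: the limit of > 100 ug/mL in this assay, at which 1 of the 4 values shown sits.

The single change swaps the lactam ring for a sulfur link, an aromatic ring and a hydroxyl together, so the compounds shown do not say which of these carries the step. Plain phenylsulfanyl, or an amine or a carboxylic acid in place of the hydroxyl, would begin to separate them.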